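Dichlorophenoxy in place of dimethoxyphenoxy on a piperidine ester

A few compounds are considered here, and "the series" means these few. Any claim that something is new, unique, unknown or untested is made for them only; others in the source may bear on it.

Measured so far:
compound 1, `COc1ccc(OCCCCCN2CCCC(COC(=O)c3ccccc3N3C(=O)CC(C)C3=O)C2)cc1OC`, 2000000 nM
compound 2, `O=C(OCC1CCCN(CCCCCOc2ccc(Cl)cc2)C1)c1ccccc1-c1ccccc1`, 15500 nM
compound 3, `O=C(Nc1ccncn1)c1ccccc1-c1ccccc1`, 39600 nM

Of the compounds shown here, three have been tested in an in vitro functional assay on HEK ts201 cells for antagonist activity at Neuronal acetylcholine receptor; alpha3/beta4 (Homo sapiens), read by fluorescence and calcium flux; on this read-out higher numbers stand for weaker inhibition and lower numbers for stronger inhibition. Compound 1 gives 2000000 nM, the highest of the three numbers; compound 3, at 39600 nM, is the nearest to it and compound 2, at 15500 nM, the furthest, and both gaps lie beyond the scatter. No two of these compounds differ in a single place, so no step between measured compounds can be read off.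

Compound 4, `CC1CC(=O)N(c2ccccc2C(=O)OCC2CCCN(CCCCCOc3ccc(Cl)c(Cl)c3)C2)C1=O`, has not yet been tested. It differs from compound 1 in one place: 3,4-dichlorophenyl in place of 3,4-dimethoxyphenyl on an oxygen on a saturated carbon. The ester and the rest of the chain are kept. Compound 2, which also carries a chlorinated phenoxy group on the same kind of chain but a different acid part, gives 15500 nM, far below compound 1, yet it changes more than one place, so it can only hint at the direction.

The step from compound 1 to compound 4 is expected to be downward, well beyond the scatter, as a 20-fold lower number from compound 1 to compound 4 (1.30 log units; beyond the scatter). Compound 4 is therefore estimated at 100000 nM, within a range from 20000 nM to 600000 nM.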

Compound 4, half-maximal inhibitory concentration: 9120 nM
The estimate for compound 4 lay 11-fold (1.04 log units) above the measured number, and the stated range ends above it.
By their numbers in this assay, from the lowest: compounds 4 and 2 (each within the scatter of the next); then compound 3; then compound 1.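

In this assay the exchange of 3,4-dimethoxyphenyl for 3,4-dichlorophenyl on an oxygen on a saturated carbon gives a 220-fold lower number from compound 1 to compound 4 (2.34 log units; beyond the scatter) and so marks this place as one where a single change moves the number strongly. The earlier compounds could not show this, as they differed from one another in several places at once and the high number of compound 1 could not be assigned to any one part of it; now the 3,4-dimethoxyphenyl end alone is seen to account for a large step, while the acid part, the ester and the rest of the chain stay the same. Nothing available gives a measured reason for the size of this step.

On these data alone, it remains open whether a single chlorine, a single methoxy group, a trifluoromethyl group or an unsubstituted phenyl ring in this place would give a number closer to that of compound 1 or of compound 4. As far as these compounds go, it is also open whether the same exchange would carry the same weight with the acid part of compound 2 or with a shorter or longer chain leading to the oxygen.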